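A few compounds are considered here, and "the series" means these few. Any claim that something is new, unique, unknown or untested is made for them only; others in the source may bear on it.

Within the data shown here, in a functional assay on HCT-116 cells (Homo sapiens) for antiproliferative activity, with a stated time of 72 h (a higher number here means a weaker inhibitor, a lower number a stronger inhibitor), only two compounds have values so far. Compound 1 `COc1ccc(/C=C/c2nc(Nc3cccc(O)c3)c3ccccc3n2)cc1` gives 22900 nM and compound 2 `Oc1ccc(Nc2nc(/C=C/c3cccc(Cl)c3)nc3ccccc23)cc1` gives 22700 nM, so compound 2 stands within the scatter of compound 1 and cannot be ranked apart from it. Compound 3 `Oc1cccc(Nc2nc(/C=C/c3cccc(Cl)c3)nc3ccccc23)c1` has not yet been measured. It differs from compound 2 in one group: 3-hydroxyphenyl in place of 4-hydroxyphenyl on a nitrogen on an aromatic ring, with 3-hydroxyphenyl in place of 4-hydroxyphenyl on a nitrogen on an aromatic ring. Among the measured compounds shown here, no measured pair isolates this change. Compound 1 also carries the 3-hydroxyphenyl and gives 22900 nM, so the data offer no sign of a large shift. The expected change is a 1.3-fold lower number from compound 2 to compound 3 (0.10 log units; within the scatter), a step not expected to exceed the scatter, with no firm direction. For compound 3 the estimated value is 18000 nM, with an expected range from 5000 nM to 50000 nM.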

Compound 3, half-maximal inhibitory concentration: > 25000 nM
Compound 3: only a limit was reported; the forecaster's own chance of this, stated with the estimate: 10%; middle value at least 1.3-fold (0.14 log units) away from the limit.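

In this assay the result for compound 3 is a limit of the assay and not a number: the limit of > 25000 nM in this assay, at which 1 of the 3 values shown sits.

With 3-hydroxyphenyl in place of 4-hydroxyphenyl on a nitrogen on an aromatic ring, this position has its first measured pair, which gives an at least 1.1-fold higher number from compound 2 to compound 3 (0.04 log units; that floor lies within the scatter); the pair shows no lowering of the number, but its floor cannot establish a real loss. With 3-chlorophenyl in place of 4-methoxyphenyl on a double-bonded chain carbon bound to a double-bonded chain carbon, the second pair gives an at least 1.0-fold higher number from compound 1 to compound 3 (0.03 log units; that floor lies within the scatter), again a floor that cannot separate the two compounds.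

On these data alone, how far compound 3 lies past its limit stays open, and with it the true size of both steps. Also open, as far as these compounds go, is whether an amine or a carboxylic acid in place of the hydroxyl would move the number beyond the scatter.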